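The source may report more compounds than this note shows. Statements on the series, on what has been measured and on what is new or still open speak of the compounds shown alone.

Compound 2 `CC(C)c1ccc2c(CNC(=O)CNS(=O)(=O)c3ccccc3)cc(C(=O)O)c-2cc1` sits at the edge of what a functional assay on thoracic aorta for antagonist activity at thromboxane A2 receptor (Rattus norvegicus) (a higher number here means a weaker inhibitor, a lower number a stronger inhibitor), can report: in this assay compound 2 gives > 100000 nM, a limit rather than a number. Compound 1 `CC(C)c1ccc2c(CNC(=O)CNC(=O)c3ccc(Cl)cc3)cc(C(=O)O)c-2cc1` gives > 100000 nM in this assay, again a limit. The step that the two limits leave unreadable from compound 1 to compound 2 is therefore unreadable, both values lying at the limit of > 100000 nM in this assay, at which 2 of the 2 values shown sit. Compound 3 `CC(C)c1ccc2c(CNC(=O)CNS(=O)(=O)c3ccc(Cl)cc3)cc(C(=O)O)c-2cc1` differs from compound 2 by chloro in place of hydrogen on an aromatic carbon. Within the data shown here, no measured step tracks this change, and compound 1, carrying a chloro group at the same place of its carbonyl partner, also rests at the limit. Compound 3 is thus expected to give 100000 nM, within 30000 nM to 300000 nM. The expected step is a number no higher from compound 2 to compound 3 (the limit leaves the size open).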

Compound 3, half-maximal inhibitory concentration: > 100000 nM
Compound 3: a limit, no number (the forecaster's own chance of this, stated with the estimate: 85%); the middle value sits exactly at the limit.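

In this assay, among these compounds, compound 3 rests at a limit, as do compound 1 and compound 2, so no step among them can be read. The compounds shown leave open whether either change alters inhibition at all.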